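Methoxy for fluoro: cytotoxicity notes on the series

This account rests on a few compounds, and the source may have more. Where it says the series, first, only, none or still open, it means among the compounds named here.

The compounds are compared in an ADME assay on Huh-7 cells (Homo sapiens) for cytotoxicity, with a stated time of 3 days; a higher number here means that more compound is tolerated, a lower number that less compound is tolerated. Compound 1, `O=C(Nc1cccc(C(F)(F)F)c1)c1c(NO)cc(-c2ccccc2)oc1=O`, gives 19000 nM there. Compound 2, `Cc1ccc(-c2cc(NO)c(C(=O)NC3CCCCC3)c(=O)o2)cc1`, gives 10100 nM in this assay. Compound 3, `O=C(Nc1ccc(F)cc1)c1c(NO)cc(-c2cccs2)oc1=O`, is reported in this assay only as > 20000 nM, which is a limit of the assay and not a number. Compound 3 thus stands at the tolerated end of the three values shown, at the limit recorded in the limit of > 20000 nM in this assay, at which 1 of the 3 values shown sits; how far it lies from compound 1 and compound 2 cannot be sized from a limit.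

Compound 4, `COc1ccc(NC(=O)c2c(NO)cc(-c3cccs3)oc2=O)cc1`, has not yet been measured. It differs from compound 3 by methoxy in place of fluoro on an aromatic carbon. Going by the values given here, no measured pair in this assay shows this change, so the size of the step is open. Since compound 3 already sits at the limit given in the limit of > 20000 nM in this assay, at which 1 of the 3 values shown sits, the expectation is for no step beyond the scatter, with a fair chance that compound 4 is again returned only as a limit rather than a number. The estimated step is a step that the limit leaves unreadable from compound 3 to compound 4 in this assay. Compound 4 is expected at 22000 nM, with a range from 11000 nM to 45000 nM.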

Compound 4, half-maximal cytotoxic concentration: > 20000 nM
Compound 4 was reported as a limit; the forecaster's own chance of this, stated with the estimate: 60%; the middle value is on the limit's open side.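

In this assay, going by these compounds alone, compound 4 is again only a limit (> 20000 nM), as is compound 3, so no step between compound 3 and compound 4 can be read: the limit of > 20000 nM in this assay, at which 2 of the 4 values shown sit. As far as these compounds go, what stays open is whether methoxy in place of fluoro shifts the tolerated concentration at all, and how far compound 3 and compound 4 lie from compound 1 and compound 2.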